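The source may report more compounds than this note shows. Statements on the series, on what has been measured and on what is new or still open speak of the compounds shown alone.

The compounds here share one core: a sulfonamide that joins a phenol carrying a hydroxymethyl group to a biphenyl. Compound 1 `O=S(=O)(Nc1cc(CO)ccc1O)c1ccc(-c2ccc(Br)cc2)cc1` carries a 4-bromophenyl at the far end, and in a functional assay on J774 cells (Mus musculus) for cytotoxicity, read by resazurin assay, with a stated time of 72 h (a higher number here means a weaker inhibitor, a lower number a stronger inhibitor), compound 1 gives 1000 nM. Compound 2 `O=S(=O)(Nc1cc(CO)ccc1O)c1ccc(-c2ccc(F)cc2F)cc1` swaps that ring for a 2,4-difluorophenyl, and in this assay compound 2 gives 200 nM. That change, a 5.0-fold lower number from compound 1 to compound 2 (0.70 log units; beyond the scatter), stands beyond the scatter. Compound 3 `O=S(=O)(Nc1ccc(-c2ccc(Cl)cc2Cl)cc1)c1cccc(CO)c1` turns the sulfonamide around and has no hydroxy on the aniline ring; in this assay compound 3 reaches only a limit, > 10000 nM. Of the two numbers shown, compound 2 holds the lowest.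

Compound 4 `O=S(=O)(Nc1cccc(CO)c1)c1ccc(-c2ccc(F)cc2F)cc1` keeps the 2,4-difluorophenyl of compound 2 but differs in one place: hydrogen in place of hydroxy on an aromatic carbon. For the measured compounds named here, no measured step covers this change alone. Going by the values given here, the one step on record, from compound 1 to compound 2, touched the distal ring and not the hydroxy. Among the compounds with values here, compound 3, the only compound without that hydroxy, sits at the limit (the limit of > 10000 nM in this assay, at which 1 of the 3 values shown sits), yet it also differs in the sulfonamide orientation, so it is a weak guide. From compound 2 to compound 4 a weakening, a 15-fold higher number from compound 2 to compound 4 (1.18 log units; beyond the scatter), is expected, and compound 4 is estimated in this assay at 3000 nM, ranging from 500 nM to 20000 nM.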

Compound 4, half-maximal inhibitory concentration in the J774 assay: 300 nM
Compound 4: the middle estimate sits 10-fold (1.00 log units) above what was measured, and the stated range ends above it.
By their numbers in the J774 assay, from the lowest: compounds 2 and 4 (each within the scatter of the next); then compound 1. At a limit, above all of these: compound 3.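

In the J774 assay, removing the hydroxy gives a 1.5-fold higher number from compound 2 to compound 4 (0.18 log units; within the scatter), so with the 2,4-difluorophenyl in place, this group on an aromatic carbon, para to the hydroxymethyl group, makes no readable difference to the cell result. For the compounds shown here, this is the first pair to isolate that single change, and it shows that losing the hydroxy alone does not take compound 2 to a limit like that of compound 3, which differs from compound 4 in more than one place: the limit of > 10000 nM in the J774 assay, at which 1 of the 4 values shown sits. The same swap does move a different measurement: in a physicochemical assay for solubility, read by HPLC, in simulated intestinal fluid, measured as thermodynamic solubility, with a stated time of 24 h (a lower number here means a less soluble compound, a higher number a more soluble compound), compound 2 gives 12 ug/mL and compound 4 gives 50 ug/mL. Solubility goes up when the hydroxy gives way to hydrogen: the measured solubility of compound 2, 12 ug/mL, and of compound 4, 50 ug/mL, a 4.2-fold higher number (0.62 log units; beyond the scatter).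

Going by these compounds alone, only this one pair isolates the change, so it remains open whether the hydroxy would count for as little with the 4-bromophenyl of compound 1 at the far end of the molecule. Also open, as far as these compounds go, is how an amine or a methoxy group at the same position would behave in either assay, and whether either would keep the cell result of compound 2 alongside the solubility of compound 4.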